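From 4-chloro-2-fluorophenyl to 3-carboxy-4-methoxyphenyl

The compounds below may be only part of what the source reports. "The series", "measured", "known", "first", "only" and "open" are said of these compounds alone.

Measured so far in an ADME assay on microsomes from liver (Rattus norvegicus) for metabolic stability, read by LC-MS, with a stated time of 1 h, at 37 degrees C, tested at 4 uM (on this read-out lower numbers stand for a less stable compound and higher numbers for a more stable compound), are these compounds:
compound 1 `O=C1c2ccc(OCc3cccc(-c4ccc(Cl)cc4F)c3)cc2CN1C1CCCC1` gives "not determined" (no result reported)
compound 2 `COc1ccc(C(=O)O)cc1-c1cccc(COc2ccc3c(c2)CN(C2CCCC2)C3=O)c1` gives 30%
compound 3 `O=C(O)c1cc(-c2cccc(COc3ccc4c(c3)CN(C3CCCC3)C4=O)c2)ccc1O` gives 9%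

Compound 1 has no number to start from, since in this assay compound 1 stands as "not determined" (no result reported) and offers no baseline. The change from compound 1 to compound 4 `COc1ccc(-c2cccc(COc3ccc4c(c3)CN(C3CCCC3)C4=O)c2)cc1C(=O)O` is 3-carboxy-4-methoxyphenyl in place of 4-chloro-2-fluorophenyl on an aromatic carbon and it puts 3-carboxy-4-methoxyphenyl in place of 4-chloro-2-fluorophenyl on an aromatic carbon, meta to a large group. Going by the values given here, no measured step starts from compound 1, so neither a size nor a direction can be expected for this step.

Among the compounds with values here, the only measured step is a number 21 percentage points lower from compound 2 to compound 3 (beyond the scatter) and it replaces 5-carboxy-2-methoxyphenyl with 3-carboxy-4-hydroxyphenyl. Compound 4 carries a methoxy group like compound 2 and a 3-carboxy group like compound 3, but that one step alters both features at once and cannot separate them. The shared methoxy group makes compound 2 at 30% the closer guide, so the estimate leans towards that value, with a wide range. In this assay the expected value for compound 4 is 28% with an estimated range from 10% to 55% on measurement.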

Compound 4, percent of the compound remaining: 84%
Beside the measured number, compound 4's estimate is 56 percentage points below it; measured number above the stated range.
By their numbers in this assay, from the lowest: compound 3; then compound 2; then compound 4.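

In this assay the oxygen on the aromatic ring proves decisive, since methyl in place of hydrogen there gives a number 75 percentage points higher from compound 3 to compound 4 (beyond the scatter) and is the only difference between these two compounds. The arrangement of the substituents on this ring also counts, as 3-carboxy-4-methoxyphenyl in place of 5-carboxy-2-methoxyphenyl gives a number 54 percentage points higher from compound 2 to compound 4 (beyond the scatter) even though both groups carry a carboxy and a methoxy substituent. The earlier step had changed both features at once, whereas these two steps separate them, each is large on its own, and together they place compound 4 above both compound 2 and compound 3 in this small set.

Nothing shown gives a reason for either step. The change from 4-chloro-2-fluorophenyl cannot be read in this assay, and the compounds shown leave open whether an ethoxy group could stand in place of the methoxy group, or an amine in place of the carboxylic acid, with the number kept as high as it is for compound 4.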